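Amide Variation on a Bicyclic Bcl-2 Inhibitor Scaffold

The source may hold more compounds than are shown below. What is called first, only, known or untested is meant among the compounds shown, and "the series" means these compounds.

Compound 1 `CC(C)=CCCC1=CC[C@H](C(=O)N(C)C)[C@@H](c2ccccc2)C1`: > 23000 nM
Compound 2 `CC(C)=CCCC1=CC[C@@H](C(=O)NO)[C@H](c2ccccc2)C1`: 700 nM
Compound 3 `CON(C)C(=O)[C@H]1CC=C(CCC=C(C)C)C[C@@H]1c1ccccc1`: 300 nM

Of the compounds shown here, three sharing one core have been measured in an assay on isolated protein for inhibition of Apoptosis regulator Bcl-2 (Homo sapiens), read by fluorescence polarization, with stated times of 5 min and 10 min; a higher number here means a weaker inhibitor, a lower number a stronger inhibitor. Compound 1 gives only a limit of the assay, > 23000 nM. Compound 2, which carries a hydroxyamino group on its carbonyl carbon, gives 700 nM. Compound 3 gives 300 nM, the lowest of the two real numbers shown, with compound 2 sitting a little higher, beyond the scatter. Among the measured compounds shown here, the one single-change step measured runs an at least 76-fold lower number from compound 1 to compound 3 (1.88 log units; beyond the scatter); because it starts from the limit of > 23000 nM in this assay, at which 1 of the 3 values shown sits, only its lower bound is known.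

Compound 4 `CC(C)=CCCC1=CC[C@H](C(=O)NO)[C@@H](c2ccccc2)C1` differs from compound 3 in one place: hydroxyamino in place of methoxy(methyl)amino on a carbonyl carbon. For the measured compounds named here, no measured step covers this exact change, so the expectation rests on compound 3 at 300 nM and on compound 2, which bears the same hydroxycarbamoyl group, at 700 nM. Compound 4 is therefore estimated at 500 nM, within 150 nM to 2000 nM. The expected step is a 1.7-fold higher number from compound 3 to compound 4 (0.22 log units; within the scatter), a small weakening or none beyond the scatter.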

Compound 4, inhibition constant: 600 nM
Compound 4: middle estimate off by 1.2-fold (0.08 log units), on the low side, and the stated range covers the measured number.
By their numbers in this assay, from the lowest: compounds 3, 4 and 2 (each within the scatter of the next, the first and the last beyond it). At a limit, above all of these: compound 1.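

In this assay, hydroxyamino in place of methoxy(methyl)amino on a carbonyl carbon gives a 2.0-fold higher number from compound 3 to compound 4 (0.30 log units; within the scatter), so the two groups cannot be told apart here, even though hydroxyamino is the smaller group and carries donors that the other lacks. The mirror-image pair gives a 1.2-fold lower number from compound 2 to compound 4 (0.07 log units; within the scatter), so inverting both stereocentres brings no difference beyond the scatter, and the comparison isolates handedness alone: the fact that compounds 2 and 4 differ only in the configuration as drawn. Hydroxyamino in place of dimethylamino gives an at least 38-fold lower number from compound 1 to compound 4 (1.58 log units; beyond the scatter), a step known only as a lower bound, since it starts from a limit: the limit of > 23000 nM in this assay, at which 1 of the 4 values shown sits.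

Still open, on these data alone, is whether a methylamino group or a hydroxyl group, which would make a carboxylic acid, on that carbonyl carbon would sit with compound 3 and compound 4 or with compound 1. Also open, as far as these compounds go, is whether the mirror image of compound 3 would match compound 3 in the same way.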